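The compounds below may be only part of what the source reports. "The series", "measured", "known", "first", "only" and "open" are said of these compounds alone.

Compound 1, `C#CCN(CC)Cc1cn(-c2cc(NC(=S)NCC)ncn2)cn1`, in an assay on isolated protein for inhibition of Amine oxidase [flavin-containing] B (Homo sapiens), read by fluorescence and Amplex Red, with a stated time of 15 min (on this read-out lower numbers stand for stronger inhibition and higher numbers for weaker inhibition), gives > 50000 nM, which is a limit of the assay and not a number.
Compound 2, `C#CCN(CCCC)Cc1cn(-c2cc(NC(=S)NCC)ncn2)cn1`, in this assay gives > 50000 nM, again a limit of the assay rather than a number.
Compound 3, `C#CCN(Cc1ccccc1)Cc1cn(-c2cc(NC(=S)NCC)ncn2)cn1`, in this assay gives > 50000 nM, also a limit of the assay and not a number.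

Compound 3 therefore stands where the whole set stands: at the limit of > 50000 nM in this assay, at which 3 of the 3 values shown sit. None of the three can be placed relative to the others, and the steps that join them, a step that the two limits leave unreadable from compound 1 to compound 2, a step that the two limits leave unreadable from compound 1 to compound 3 and a step that the two limits leave unreadable from compound 2 to compound 3, carry no readable size.

Compound 4, `C#CCN(CC#N)Cc1cn(-c2cc(NC(=S)NCC)ncn2)cn1`, is the next member. Its change from compound 3 is cyano in place of phenyl on a saturated chain carbon bound to an amine nitrogen. Every measured step alters the same substituent on the amine nitrogen and none of them moved a compound off the limit, so no direction and no size can be read for this step either. The expectation for compound 4 is simply that it too is most likely reported at the limit, and the estimated step that the limit leaves unreadable from compound 3 to compound 4 is accordingly set at none beyond the scatter. The estimate for compound 4 in this assay is 60000 nM, with a range from 20000 nM to 200000 nM.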

Compound 4, half-maximal inhibitory concentration: > 50000 nM
Compound 4: a limit, no number; the forecaster's own chance of this, stated with the estimate: 85%; the middle value does not contradict the limit.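

Compound 1, compound 2, compound 3 and compound 4 all stand at a limit of the assay and not at a number, so no step among them can be read: the limit of > 50000 nM in this assay, at which 4 of the 4 values shown sit.

As far as these compounds go, the order of these four compounds stays open, as does whether any other group on the amine nitrogen would give a number in this assay.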